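The compounds below may be only part of what the source reports. "The series", "measured", "known", "first", "only" and "open" are said of these compounds alone.

Measured compounds:
Compound 1, `Cc1cccc(/C(N)=N/NC(=S)N2CCCCC2)n1`, gives 43% in a functional assay on MCF7 cells (Homo sapiens) for cytotoxicity, read by MTT assay, with a stated time of 72 h, tested at 30 uM; a higher number here means more inhibition of growth at the concentration tested, a lower number less inhibition of growth.
Compound 2, `Cc1ccnc(/C(N)=N/NC(=S)N2CCCCCC2)c1`, gives 75.9% in this assay.
Compound 3, `N/C(=N\NC(=S)N1CCOCC1)c1ccc(F)cn1`, gives 56.7% in this assay.

Among these three numbers compound 1 stands lowest; compound 3 is the nearest to it and compound 2 the furthest, both gaps beyond the scatter. Compounds 2 and 3 differ from compound 1 in more than one place, so no single change can be read from them.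

Compound 4, `Cc1cccc(/C(N)=N/NC(=S)N2CCCC2)n1`, differs from compound 1 in one place: pyrrolidin-1-yl in place of piperidin-1-yl on a thiocarbonyl carbon. Within the data shown here, nothing among the measured compounds isolates the ring size on the thiocarbonyl carbon, so for this step no change beyond the scatter is expected in this assay in either direction. The number expected for compound 4 is 43%, within 25% to 62%, a step from compound 1 to compound 4 estimated as no change at the digits printed from compound 1 to compound 4 (within the scatter).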

Compound 4, percent growth inhibition at one concentration: 40.1%
Compound 4: middle estimate off by 2.9 percentage points, on the high side, within the range that was stated.
By their numbers in this assay, from the lowest: compounds 4 and 1 (each within the scatter of the next); then compound 3; then compound 2.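

In this assay the thiocarbonyl carbon now has its first single-change comparison: with pyrrolidin-1-yl in place of piperidin-1-yl, the result is a number 2.9 percentage points lower from compound 1 to compound 4 (within the scatter), so these two ring sizes are not told apart on the core of compound 1. No supporting measurement bears on this result. Still open, going by these compounds, is whether the same holds on a different core, and whether an open-chain group such as diethylamino on the thiocarbonyl carbon would read alike.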